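A few compounds are considered here, and "the series" means these few. Any claim that something is new, unique, unknown or untested is made for them only; others in the source may bear on it.

Measured in an in vitro assay on P815B cells for inhibition of Indoleamine 2,3-dioxygenase 1 (Mus musculus), tested at 20 uM; on this read-out higher numbers stand for more inhibition at the one concentration tested (going by the name of the read-out) and lower numbers for less inhibition:

Compound 1 `O=C(Cc1cccnc1)c1cc2c(F)cccc2[nH]1` — 12%
Compound 2 `O=C(Cc1cccnc1)c1cc2cc(Br)ccc2[nH]1` — "not active" (no number reported)
Compound 3 `c1cncc(CCc2cc3ccccc3[nH]2)c1` — "not active" (no number reported)

Of the three measured compounds only compound 1 comes with a number in this assay, and that number is small. Compound 2 and compound 3 are reported as not active without any number, so nothing can be said about how far they stand from compound 1. Among the compounds with values here, since no two compounds here differ in a single place, there is no measured step to lean on.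

Compound 4 `COc1cccc2[nH]c(C(=O)Cc3cccnc3)cc12` is the compound still to be measured. Compared with compound 1 it carries methoxy in place of fluoro on an aromatic carbon. Within the data shown here, with only one number in hand and two entries that give none, the expectation for this change can rest on little more than the weak result of compound 1 itself. The step expected from compound 1 to compound 4, a number 2 percentage points lower from compound 1 to compound 4 (within the scatter), is none beyond the usual scatter, in either direction. For compound 4 in this assay the estimate is therefore 10%, with a range from 0% to 25%, and a fair chance that it too is simply reported as not active without a number.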

Compound 4, a percentage reported as inhibition, at one concentration (the size of the read-out at that concentration, not a potency): "not active" (no number reported)
Compound 4 has no reported number here; the estimate stays without a comparison.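

Within the data shown here, compound 4 is reported as not active in this assay with no number, so no step from compound 1 can be read. Going by these compounds, whether swapping fluoro for methoxy changes inhibition by more than the usual scatter stays open. Nothing measured here offers an explanation for this result.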